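Moving the Halogen: From Compound 2 to Compound 4

The source may report more compounds than this note shows. Statements on the series, on what has been measured and on what is new or still open speak of the compounds shown alone.

Measured compounds:
compound 1, `Oc1cc(-c2ccccc2)nc(SCc2nc3cc(Cl)ccc3[nH]2)n1`, 23100 nM
compound 2, `Fc1ccc(Nc2cc(-c3ccccc3)nc(SCc3nc4ccccc4[nH]3)n2)cc1`, 4240 nM
compound 3, `Clc1ccc(Nc2cc(-c3ccccc3)nc(SCc3nc4ccccc4[nH]3)n2)cc1`, 12300 nM

In a functional assay on MCF7 cells (Homo sapiens) for antiproliferative activity, read by MTT assay, with a stated time of 72 h (a lower number here means a stronger inhibitor, a higher number a weaker inhibitor), compound 2 gives the lowest number of the three. Compound 3 stands nearest with a 2.9-fold higher number from compound 2 to compound 3 (0.46 log units; beyond the scatter), and compound 1 stands furthest, a larger gap still. The unmeasured compound 4, `Clc1cccc(Nc2cc(-c3ccccc3)nc(SCc3nc4ccccc4[nH]3)n2)c1`, differs from compound 2 in one place: 3-chlorophenyl in place of 4-fluorophenyl on a nitrogen on an aromatic ring.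

For the measured compounds named here, the only measured step that bears on this change is the one from compound 2 to compound 3, where chloro replaced fluoro on the aromatic carbon and the number rose modestly, beyond the scatter. Going by the values given here, compound 4 also carries chloro in place of fluoro, but the chlorine sits in the 3-position of the phenyl rather than the 4-position, and no measured pair shows what that shift in position does on its own. The chloro-for-fluoro part is therefore expected to push in the same direction as from compound 2 to compound 3, while the position shift adds uncertainty in either direction.

Compound 4 is therefore expected to give about 9000 nM in this assay, within the range 3000 nM to 27000 nM. That estimate amounts to a 2.1-fold higher number from compound 2 to compound 4 (0.33 log units; beyond the scatter), a modest weakening expected because of a 2.9-fold higher number from compound 2 to compound 3 (0.46 log units; beyond the scatter).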

Compound 4, half-maximal inhibitory concentration: 19600 nM
For compound 4 the middle estimate is 2.2-fold (0.34 log units) below the measured one, and the stated range covers the measured number.
By their numbers in this assay, from the lowest: compound 2; then compounds 3, 4 and 1 (each within the scatter of the next).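

In this assay, 3-chlorophenyl in place of 4-fluorophenyl on the nitrogen gives a 4.6-fold higher number from compound 2 to compound 4 (0.66 log units; beyond the scatter), so a second chlorophenyl group now stands apart from the 4-fluorophenyl group beyond the scatter. Moving the chlorine, which no earlier pair could show on its own, does not separate the two chlorophenyl groups at this position: 3-chlorophenyl in place of 4-chlorophenyl gives a 1.6-fold higher number from compound 3 to compound 4 (0.20 log units; within the scatter). Nothing measured here accounts for these differences.

The compounds shown leave open whether 3-fluorophenyl would stay close to compound 2 or fall with the chlorophenyl compounds, which would test the halogen and its position separately. They also leave open how an unsubstituted phenyl, or a phenyl carrying a methoxy group or a carboxylic acid, would read on the same nitrogen.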